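Swapping a sulfonyl substituent on a prostaglandin D2 receptor 2 ligand

A few compounds are considered here, and "the series" means these few. Any claim that something is new, unique, unknown or untested is made for them only; others in the source may bear on it.

Measured so far:
compound 1, `Cc1ccc(S(=O)(=O)CCO)cc1C#Cc1cc(Cl)ccc1OCC(=O)O`: 19 nM
compound 2, `CS(=O)(=O)c1cccc(C#Cc2cc(Cl)ccc2OCC(=O)O)c1`: 15 nM
compound 3, `CCCS(=O)(=O)c1ccc(F)c(C#Cc2cc(Cl)ccc2OC(C)C(=O)O)c1`: 3 nM

In an assay on CHO cells for displacement of a labelled ligand from prostaglandin D2 receptor 2 (Homo sapiens), read by scintillation counting (on this read-out higher numbers stand for weaker inhibition and lower numbers for stronger inhibition), compound 1 gives 19 nM, the highest of the three numbers. Compound 2 sits close to it, within the usual scatter, while compound 3 gives a clearly lower number. The new compound 4, `CNS(=O)(=O)c1ccc(C)c(C#Cc2cc(Cl)ccc2OCC(=O)O)c1`, keeps the shared core of compound 1 and differs in one place: methylamino in place of 2-hydroxyethyl on a sulfonyl sulfur. Compound 2 shows that a small group on the sulfonyl sulfur also gives a number close to that of compound 1, so no large move is expected from this change. Compound 4 is therefore expected to give about 20 nM in this assay, within 7 nM to 60 nM, a step of a 1.1-fold higher number from compound 1 to compound 4 (0.02 log units; within the scatter) that should stay within the scatter.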

Compound 4, inhibition constant: 10 nM
The estimate for compound 4 lay 2.0-fold (0.30 log units) above the measured number; measured number inside the range.
By their numbers in this assay, from the lowest: compound 3; then compounds 4, 2 and 1 (each within the scatter of the next).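

In this assay, methylamino in place of 2-hydroxyethyl on a sulfonyl sulfur gives a 1.9-fold lower number from compound 1 to compound 4 (0.28 log units; within the scatter), so the two compounds cannot be told apart. This first direct comparison at this position shows that a group attached through nitrogen can stand on the sulfonyl sulfur without a step beyond the scatter. Nothing shown here gives a reason for this result. The compounds shown leave open whether a plain amino group or a larger dimethylamino or morpholine group on that sulfur would keep the number in the same range. Also open, going by these compounds, is whether a longer chain, such as 3-hydroxypropyl, would do the same.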